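The compounds below may be only part of what the source reports. "The series", "measured", "known", "first", "only" and "open" are said of these compounds alone.

Compound 1 `CNC(=O)c1ccc(Sc2ccc(NC(=S)Nc3ccc(Cl)cc3)cc2)nc1` is one of three analogues measured in a functional assay on B16-BL6 cells (Mus musculus) for cytotoxicity, read by MTT assay, with a stated time of 48 h; on this read-out lower numbers stand for stronger inhibition and higher numbers for weaker inhibition. Among the numbers shown it stands highest: in this assay compound 1 gives 69300 nM. Its nearest neighbour is compound 3 `CNC(=O)c1ccc(Sc2ccc(NC(=S)Nc3ccc(Cl)c(C(F)(F)F)c3)cc2)nc1`, which in this assay gives 23500 nM; the change that separates them, trifluoromethyl in place of hydrogen on an aromatic carbon, is a 2.9-fold lower number from compound 1 to compound 3 (0.47 log units; beyond the scatter). Compound 2 `CNC(=O)c1ccc(Sc2ccc(NC(=S)Nc3ccc(OC(F)(F)F)cc3)cc2)nc1` in this assay gives only a limit, > 100000 nM; that is the limit of > 100000 nM in this assay, at which 1 of the 3 values shown sits. The change from compound 1 to compound 2, trifluoromethoxy in place of chloro on an aromatic carbon, reads as an at least 1.4-fold higher number from compound 1 to compound 2 (0.15 log units; that floor lies within the scatter).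

Compound 4 `CNC(=O)c1ccc(Sc2ccc(NC(=S)Nc3ccc(F)c(F)c3)cc2)nc1` is the next analogue, not yet measured in this assay. It differs from compound 1 by 3,4-difluorophenyl in place of 4-chlorophenyl on an amide-type nitrogen. Neither measured step is the same change: one adds trifluoromethyl and lowers the number, the other swaps chloro for trifluoromethoxy and reaches the limit. For compound 4 no more than a small step is therefore expected, if anything towards a higher number, with a real chance that only a limit is reported. The estimate for compound 4 in this assay is 75000 nM, between 30000 nM and 150000 nM, which is expected to be a 1.1-fold higher number from compound 1 to compound 4 (0.03 log units; within the scatter).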

Compound 4, half-maximal inhibitory concentration: 52600 nM
Beside the measured number, compound 4's estimate is 1.4-fold (0.15 log units) above it; measured number inside the range.
By their numbers in this assay, from the lowest: compound 3; then compounds 4 and 1 (each within the scatter of the next). At a limit, above all of these: compound 2.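

In this assay, putting 3,4-difluorophenyl in place of 4-chlorophenyl on the amide-type nitrogen reads as a 1.3-fold lower number from compound 1 to compound 4 (0.12 log units; within the scatter), so the two compounds cannot be told apart here. Going by these compounds alone, this is the first sign that the chloro of compound 1 is not needed to keep a measured number at this place, since a ring bearing two fluorines and no chlorine serves as well within the scatter; the earlier compounds showed only an added trifluoromethyl, with a step beyond the scatter, and a swap to trifluoromethoxy that ended in a limit. Nothing in the data shown accounts for this result.

The compounds shown leave open how this place responds to groups on the ring that carry no halogen at all, such as a methoxy, an amine or a carboxylic acid. They also leave open whether a longer chain in place of the methyl on the amide of the shared core would matter in this assay.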